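Methyl for Fluoro on a Weak Indoleamine 2,3-Dioxygenase Inhibitor

A few compounds are considered here, and "the series" means these few. Any claim that something is new, unique, unknown or untested is made for them only; others in the source may bear on it.

Measured so far:
compound 1 `O=C(Cc1cccnc1)c1cc2cc(F)ccc2[nH]1`: 36000 nM
compound 2 `O=C(Cc1ccncc1)c1cc2ccccc2[nH]1`: "not active" (no number reported)
compound 3 `c1cncc(CCc2cc3ccccc3[nH]2)c1`: "not active" (no number reported)

Among the measured compounds shown here, in an assay on isolated protein for inhibition of Indoleamine 2,3-dioxygenase 1 (Homo sapiens), read by spectrophotometry (on this read-out lower numbers stand for stronger inhibition and higher numbers for weaker inhibition), compound 1 gives 36000 nM, the only number among the three; compound 2 and compound 3 come back without one. Compound 4 `Cc1ccc2[nH]c(C(=O)Cc3cccnc3)cc2c1` differs from compound 1 in one place: methyl in place of fluoro on an aromatic carbon. For the measured compounds named here, no measured pair shows a step of this kind, so nothing here says which way it should move. Since compound 1 gives 36000 nM, the expectation for compound 4 is a number in the same weak region, with a step of a 1.1-fold higher number from compound 1 to compound 4 (0.05 log units; within the scatter) that stays within the usual scatter. Compound 4 is therefore estimated at 40000 nM, expected between 12000 nM and 130000 nM.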

Compound 4, half-maximal inhibitory concentration: 87000 nM
Beside the measured number, compound 4's estimate is 2.2-fold (0.34 log units) below it; the measured number falls inside the stated range.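

Methyl in place of fluoro on this aromatic carbon gives a 2.4-fold higher number from compound 1 to compound 4 (0.38 log units; beyond the scatter) and so somewhat weaker inhibition. Among the compounds shown here, this is the first readable step, and it shows that the group at this position can shift the number, although both compounds remain weak inhibitors. No measurement shown accounts for the shift.

One step cannot show whether the trend extends to other groups. From the compounds shown here alone, it remains open how chloro, methoxy or an amine on the same carbon would compare with fluoro and methyl.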